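The compounds below may be only part of what the source reports. "The series", "measured", "known", "first", "only" and "open" are said of these compounds alone.

Working notes on the series.

Compound 1 `CCCCCCCCCCC(=O)NCC(C)(C)CC1=C(O)C(=O)c2ccccc2C1=O` and compound 2 `CCCCCCCCCCCC(=O)NCC(C)(C)CC1=C(O)C(=O)c2ccccc2C1=O` share a core; compound 3 `CCCCCCCCCCC(=O)OCC(C)(C)CC1=C(O)C(=O)c2ccccc2C1=O` and compound 4 `CCCCCCCCCCCC(=O)OCC(C)(C)CC1=C(O)C(=O)c2ccccc2C1=O` share a second core. How the core of compound 3 differs from that of compound 1 is not broken down here.

In a functional assay on KB cells (Homo sapiens) for cytotoxicity, read by resazurin assay, with a stated time of 3 days (a lower number here means a stronger inhibitor, a higher number a weaker inhibitor), compound 1 gives 17600 nM. In this assay compound 2 gives 12800 nM. The change between them is methyl in place of hydrogen on a saturated chain carbon, ten or more bonds along the chain from a carbonyl carbon and it made a step of a 1.4-fold lower number from compound 1 to compound 2 (0.14 log units; within the scatter).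

In this assay compound 3 gives 54800 nM, which stands highest among the three measured numbers, beyond the scatter against both compound 1 and compound 2. Compound 4 has not yet been measured in this assay. The change from compound 3 to compound 4 is methyl in place of hydrogen on a saturated chain carbon, ten or more bonds along the chain from a carbonyl carbon, the same change as that from compound 1 to compound 2, placed identically on the chain, only on the second core.

Within the data shown here, the step from compound 3 to compound 4 is expected to be a 1.4-fold lower number from compound 3 to compound 4 (0.14 log units; within the scatter), because the one earlier instance of this change gave a 1.4-fold lower number from compound 1 to compound 2 (0.14 log units; within the scatter), a step within the scatter. On that basis compound 4 is estimated at 40000 nM, with the expected range running from 20000 nM to 80000 nM.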

Compound 4, half-maximal inhibitory concentration: 35700 nM
The estimate for compound 4 lay 1.1-fold (0.05 log units) above the measured number, within the range that was stated.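

In this assay, methyl in place of hydrogen on a saturated chain carbon, ten or more bonds along the chain from a carbonyl carbon, gives a 1.5-fold lower number from compound 3 to compound 4 (0.19 log units; within the scatter). Set beside the earlier instance, the change carries from the core of compound 1 to the core of compound 3 with no difference that can be read: the same change on two cores in this assay, a 1.4-fold lower number (0.14 log units; within the scatter) from compound 1 to compound 2 and a 1.5-fold lower number (0.19 log units; within the scatter) from compound 3 to compound 4, 1.1-fold (0.05 log units) apart, within the scatter of two such steps. This agreement is between two small steps, each within the scatter, so it does not show that the added methyl has a real effect on either core, and two instances in a single assay do not establish a rule for other cores in the series.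

Still open, on these data alone, is whether a much longer chain, or a chain ending in an amine or a carboxylic acid, would give a step beyond the scatter. If so, it also remains to be seen whether such a step would be the same size on both cores.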